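Benzyl ether swaps and tolerated concentration in this series

This account rests on a few compounds, and the source may have more. Where it says the series, first, only, none or still open, it means among the compounds named here.

In an ADME assay on Huh-5-2 cells (Homo sapiens) for cytotoxicity, read by WST assay, with a stated time of 3 days (a lower number here means that less compound is tolerated, a higher number that more compound is tolerated), compound 1 `Cc1ccccc1COc1cc(O)c2c(=O)c(O)c(-c3ccccc3)oc2c1` gives 17000 nM and compound 2 `N#Cc1cccc(COc2cc(O)c3c(=O)c(O)c(-c4ccccc4)oc3c2)c1` gives 72000 nM. Compound 3 `COc1cccc(COc2cc(O)c3c(=O)c(O)c(-c4ccccc4)oc3c2)c1` reaches only a limit of this assay, > 100000 nM, so its place on the numbers shown is known only as the limit of > 100000 nM in this assay, at which 1 of the 3 values shown sits. The measured steps run a 4.2-fold higher number from compound 1 to compound 2 (0.63 log units; beyond the scatter) and an at least 5.8-fold higher number from compound 1 to compound 3 (0.76 log units; beyond the scatter), while the cyano-to-methoxy swap is an at least 1.3-fold higher number from compound 2 to compound 3 (0.14 log units; that floor lies within the scatter). Compound 4 `N#Cc1ccc(COc2cc(O)c3c(=O)c(O)c(-c4ccccc4)oc3c2)cc1` differs from compound 3 by 4-cyanophenyl in place of 3-methoxyphenyl on a saturated chain carbon bound to an oxygen on an aromatic ring. The nearest measured precedent is that last step, which stayed within the scatter, so for compound 4 an expected step of an at least 1.1-fold lower number from compound 3 to compound 4 (0.07 log units; that floor lies within the scatter) is estimated, leaning toward the number of compound 2 at 72000 nM. Compound 4 is therefore expected near 85000 nM, within 40000 nM to 180000 nM.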

Compound 4, half-maximal cytotoxic concentration: 94000 nM
Compound 4: the middle estimate sits 1.1-fold (0.04 log units) below what was measured, within the range that was stated.
By their numbers in this assay, from the lowest: compound 1; then compounds 2 and 4 (each within the scatter of the next). At a limit, above all of these: compound 3.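

In this assay, 4-cyanophenyl in place of 3-cyanophenyl gives a 1.3-fold higher number from compound 2 to compound 4 (0.12 log units; within the scatter), so the place of the nitrile on this benzyl ring makes no difference that can be told from scatter. The 4-cyanophenyl group also separates clearly from 2-methylphenyl, with a 5.5-fold higher number from compound 1 to compound 4 (0.74 log units; beyond the scatter). Compound 3 remains a limit of the assay, and an at least 1.0-fold lower number from compound 3 to compound 4 (0.02 log units; that floor lies within the scatter) sets no order: the limit of > 100000 nM in this assay, at which 1 of the 4 values shown sits.

From the compounds shown here alone, it stays open whether the lower number of compound 1 belongs to the methyl group or to its place in 2-methylphenyl. Going by these compounds, how a benzyl ring carrying an amine or a carboxylic acid would read in this assay also stays open.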